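Quinoxaline sulfones: swapping the aryl substituent on the anilino nitrogen

The source may hold more compounds than are shown below. What is called first, only, known or untested is meant among the compounds shown, and "the series" means these compounds.

Measured compounds:
compound 1 `COc1ccc(S(=O)(=O)c2nc3ccccc3nc2Nc2ccccc2)cc1`, 1260 nM
compound 2 `COc1ccc(S(=O)(=O)c2nc3ccccc3nc2Nc2cc(OC)cc(OC)c2)cc1`, 6220 nM
compound 3 `COc1ccc(S(=O)(=O)c2nc3ccccc3nc2Nc2cccc(N)c2)cc1`, 8600 nM

In a functional assay on PC-3 cells (Homo sapiens) for cytotoxicity, read by MTT assay, with a stated time of 72 h (a lower number here means a stronger inhibitor, a higher number a weaker inhibitor), compound 3 gives the highest of the three numbers; compound 2 lies nearest, within the scatter, while compound 1 lies furthest, with a 6.8-fold higher number from compound 1 to compound 3 (0.83 log units; beyond the scatter) separating them. Compound 4 `COc1ccc(S(=O)(=O)c2nc3ccccc3nc2Nc2ccc(C(F)(F)F)cc2)cc1` differs from compound 3 in one place: 4-(trifluoromethyl)phenyl in place of 3-aminophenyl on a nitrogen on an aromatic ring.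

Among the measured compounds shown here, two measured steps bear on this change. Going from the plain phenyl of compound 1 to a substituted ring raised the number in both cases: a 4.9-fold higher number from compound 1 to compound 2 (0.69 log units; beyond the scatter) and a 6.8-fold higher number from compound 1 to compound 3 (0.83 log units; beyond the scatter). The move to compound 4 removes the amino group that accompanied the larger number in compound 3, but it introduces another substituent, and each substituted ring seen so far sat above compound 1. The writer therefore expects compound 4 to fall between compound 1 and compound 3, with a 2.9-fold lower number from compound 3 to compound 4 (0.46 log units; beyond the scatter) as a modest step toward a lower number in this assay. The estimate for compound 4 is 3000 nM, with a range from 1000 nM to 9000 nM.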

Compound 4, half-maximal inhibitory concentration: 330 nM
Beside the measured number, compound 4's estimate is 9.1-fold (0.96 log units) above it; measured number outside the range, below it.
By their numbers in this assay, from the lowest: compound 4; then compound 1; then compounds 2 and 3 (each within the scatter of the next).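

In this assay, a substituted ring on this nitrogen no longer goes only with a higher number: a 3.8-fold lower number from compound 1 to compound 4 (0.58 log units; beyond the scatter) runs the other way from the rises seen for compound 2 and compound 3 relative to compound 1. The gaps to those two substituted rings are wider still, with a 19-fold lower number from compound 2 to compound 4 (1.28 log units; beyond the scatter) and a 26-fold lower number from compound 3 to compound 4 (1.42 log units; beyond the scatter) showing that at this place the identity of the substituted ring matters, not merely the presence of a substituent, and leaving compound 4 as the most potent of the four. Nothing measured here accounts for these differences.

From the compounds shown here alone, whether a nitrile, a chlorine or a methyl group in place of the trifluoromethyl would also give a low number remains open. Equally open, going by these compounds, is whether 4-(trifluoromethyl)phenyl keeps its number when the methoxy group on the shared core gives way to a fluorine or an amine.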